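Double-bond geometry and cytotoxicity in a small series

This account rests on a few compounds, and the source may have more. Where it says the series, first, only, none or still open, it means among the compounds named here.

Of the compounds shown here, two have been measured in an ADME assay on RAW264.7 cells (Mus musculus) for cytotoxicity, read by luminescence and CellTiter-Glo, with a stated time of 18 h, tested at 5 uM; a higher number here means a weaker effect of the compound at the concentration tested, a lower number a stronger effect. Compound 1 `C=C1CC[C@H]2C(C)(C)CCC[C@]2(C)[C@H]1C/C=C1/C(=O)OC[C@H]1O` gives 82.7%, and compound 2 `C=C1CC[C@H]2C(C)(C)CCC[C@]2(C)[C@H]1C/C=C1\C=COC1=O` gives 90.8%; compound 1 holds the lower of the two numbers, though the gap to compound 2 lies within the scatter. Compound 3 `C=C1CC[C@H]2C(C)(C)CCC[C@]2(C)[C@H]1C/C=C1\C(=O)OC[C@H]1O` is still to be measured in this assay. It differs from compound 1 as follows: the two compounds have the same atoms and bonds and differ only in configuration as drawn: 1 of 5 stereo elements differ; a double bond is drawn E in compound 1 and Z in compound 3. Among the measured compounds shown here, no step between measured compounds covers such a change, so no shift beyond the scatter is expected in either direction. For compound 3 the value is estimated at 84%, with a range from 70% to 96%. The expected step in this assay is therefore a number 1.3 percentage points higher from compound 1 to compound 3 (within the scatter).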

Compound 3, a percentage reported as activity, at one concentration (the size of the read-out at that concentration, not a potency): 81.7%
Compound 3: middle estimate off by 2.3 percentage points, on the high side; the measured number falls inside the stated range.
By their numbers in this assay, from the lowest: compounds 3, 1 and 2 (each within the scatter of the next).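

In this assay, turning the double bond from E to Z gives a number 1 percentage points lower from compound 1 to compound 3 (within the scatter). At the tested concentration, the geometry of this double bond therefore does not separate the two compounds, a reading that the earlier pair could not give, as compound 2 differs from compound 1 in more than configuration. The comparison isolates this one change: the fact that compounds 1 and 3 differ only in the configuration as drawn. Still open, from the compounds shown here alone, is whether an amine or a carboxylic acid in place of the hydroxyl would shift the number beyond the scatter. A single concentration also shows the size of the effect at that concentration only and leaves other concentrations unread.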